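The source may report more compounds than this note shows. Statements on the series, on what has been measured and on what is new or still open speak of the compounds shown alone.

Three compounds sharing one core have numbers in a functional assay on MCF7 cells (Homo sapiens) for cytotoxicity, read by MTT assay, with a stated time of 24 h; a lower number here means a stronger inhibitor, a higher number a weaker inhibitor. Compound 1 `COc1ccc(/C=C(\C#N)C(=O)N/N=C(\C)c2c(O)c3ccc(O)cc3oc2=O)cc1OC`, which carries a 3,4-dimethoxyphenyl group, gives 14400 nM. Compound 2 `COc1ccc(/C=C(\C#N)C(=O)N/N=C(\C)c2c(O)c3ccc(O)cc3oc2=O)cc1` gives 8940 nM, and compound 3 `C/C(=N\NC(=O)/C(C#N)=C/c1ccc([N+](=O)[O-])cc1)c1c(O)c2ccc(O)cc2oc1=O` gives 8200 nM. Compound 1 lies within the scatter of both others, so these three numbers cannot be ranked.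

The unmeasured compound 4 `C/C(=N\NC(=O)/C(C#N)=C/c1ccccc1[N+](=O)[O-])c1c(O)c2ccc(O)cc2oc1=O` has 2-nitrophenyl in place of 3,4-dimethoxyphenyl on a double-bonded chain carbon bound to a double-bonded chain carbon.

The closest measured change is a 1.8-fold lower number from compound 1 to compound 3 (0.24 log units; within the scatter), where 4-nitrophenyl takes the place of 3,4-dimethoxyphenyl at that same carbon. Hydrogen in place of methoxy on an aromatic carbon gives a 1.6-fold lower number from compound 1 to compound 2 (0.21 log units; within the scatter). Nitro in place of methoxy on an aromatic carbon gives a 1.1-fold lower number from compound 2 to compound 3 (0.04 log units; within the scatter). Among the measured compounds shown here, all three steps stay within the scatter, and no measured compound carries a 2-nitrophenyl group, so the data on this exact group are missing.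

In this assay, no step beyond the scatter is therefore expected, and any direction is only tentative. The estimated step is a 1.5-fold lower number from compound 1 to compound 4 (0.18 log units; within the scatter), resting on the step to compound 3 and remaining within the scatter. For compound 4 the estimated value is 9500 nM, with an expected range from 4500 nM to 20000 nM.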

Compound 4, half-maximal inhibitory concentration: 9180 nM
For compound 4 the middle estimate is 1.0-fold (0.01 log units) above the measured one, within the range that was stated.
By their numbers in this assay, from the lowest: compounds 3, 2, 4 and 1 (each within the scatter of the next).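

In this assay, the 2-nitrophenyl group on this double-bonded chain carbon gives a 1.6-fold lower number from compound 1 to compound 4 (0.20 log units; within the scatter), and moving from 4-nitrophenyl to 2-nitrophenyl gives a 1.1-fold higher number from compound 3 to compound 4 (0.05 log units; within the scatter), so these data cannot tell the two nitrophenyl groups apart. Replacing 4-methoxyphenyl with 2-nitrophenyl gives a 1.0-fold higher number from compound 2 to compound 4 (0.01 log units; within the scatter), which means that all four groups seen at this carbon, including both methoxy-bearing and both nitro-bearing ones, now sit within the scatter of one another and still cannot be ranked. No other information is available here to account for these numbers.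

As far as these compounds go, it remains open whether a carboxylic acid or an amine on the phenyl ring, or a longer alkyl chain in place of that ring, would give a step beyond the scatter at this carbon. The rest of the shared core is the same in all four compounds, so these numbers also say nothing about how a change elsewhere, such as replacing either hydroxyl group with a methoxy group, would act in this assay.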